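The source may report more compounds than this note shows. Statements on the series, on what has been measured and on what is new or still open speak of the compounds shown alone.

Working notes on the series.

The shared core carries a methoxy-bearing aromatic ring with a free hydroxyl and a phenyl group, as in compound 1 `COc1c(O)cc(O)c2c(=O)cc(-c3ccc(Cl)cc3)oc12`, compound 2 `COc1c(OCc2nc3ccccc3[nH]2)cc(O)c2c(=O)cc(-c3ccccc3)oc12` and compound 3 `CCCNCCOc1c(O)cc(O)c2c(=O)cc(-c3ccccc3)oc12`. In a functional assay on A549 cells (Homo sapiens) for cytotoxicity, read by MTT assay, with a stated time of 48 h (on this read-out lower numbers stand for stronger inhibition and higher numbers for weaker inhibition), compound 1 gives "not determined" (no result reported). In this assay compound 3 likewise gives "not determined" (no result reported). Within the data shown here, compound 2 is the only member with a recorded result, and that result is a limit of the assay rather than a number: in this assay compound 2 gives > 100000 nM. Among the measured compounds shown here, compound 2 therefore stands at the limit (the limit of > 100000 nM in this assay, at which 1 of the 3 values shown sits), and no measured step between two compounds exists.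

Compound 4 `COc1c(OCCCN2CCCC2)cc(O)c2c(=O)cc(-c3ccccc3)oc12` is the next member to be tested. It differs from compound 2 by the change (2-(pyrrolidin-1-yl)ethyl in place of 1H-benzimidazol-2-yl on a saturated chain carbon bound to an oxygen on an aromatic ring). For the measured compounds named here, with no measured step to lean on, the expectation for compound 4 is a move toward stronger inhibition of a size around an at least 2.5-fold lower number from compound 2 to compound 4 (0.39 log units; beyond the scatter), beyond the usual scatter but uncertain in both directions. Compound 4 is accordingly estimated in this assay at 40000 nM, within a range from 8000 nM to 200000 nM.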

Compound 4, half-maximal inhibitory concentration: 1390 nM
Compound 4: middle estimate off by 29-fold (1.46 log units), on the high side, outside the stated range (below it).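

In this assay, among these compounds, 2-(pyrrolidin-1-yl)ethyl in place of 1H-benzimidazol-2-yl on a saturated chain carbon bound to an oxygen on an aromatic ring gives an at least 71-fold lower number from compound 2 to compound 4 (1.85 log units; beyond the scatter), the first readable step. The result shows that the group at this position can decide whether the series gives a number or only a limit in this assay. The value for compound 2 is a limit and not a number, so the step gives only a minimum size: the limit of > 100000 nM in this assay, at which 1 of the 4 values shown sits.

The step does not separate the loss of the benzimidazole from the gain of the pyrrolidine or from the change in the chain. A morpholine or a dimethylamino group on the same 3-carbon propyl chain, or a pyrrolidine on a longer chain, would bear on that question.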